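This account rests on a few compounds, and the source may have more. Where it says the series, first, only, none or still open, it means among the compounds named here.

In a functional assay on HCT-116 cells (Homo sapiens) for cytotoxicity, read by sulforhodamine B assay, with a stated time of 72 h (a lower number here means a stronger inhibitor, a higher number a weaker inhibitor), compound 1 `OCC1=C(F)[C@@H](n2cnc3c(O)ncnc32)[C@H](O)[C@@H]1O` reaches only a limit, > 100000 nM. Among the compounds with values here, compound 2 `CNc1ncnc2c1ncn2[C@@H]1C(F)=C(CO)[C@@H](O)[C@H]1O` gives 2140 nM, the only actual number so far. Within the data shown here, the one measured step, an at least 46-fold lower number from compound 1 to compound 2 (1.66 log units; beyond the scatter), came with methylamino in place of hydroxy on an aromatic carbon. Compound 3 `OCC1=C(F)[C@@H](n2cnc3c(NC4CC4)ncnc32)[C@H](O)[C@@H]1O` keeps that nitrogen and changes what it carries: cyclopropyl in place of methyl on a nitrogen on an aromatic ring. The measured step bears on this only loosely, for it exchanged the whole group and its size is open-ended. Among the measured compounds shown here, no measured step tests a change of the group on that nitrogen, and compound 2 remains the sole guide. A modest rise in the number is expected in this assay, not far beyond the scatter, with an estimated 2.3-fold higher number from compound 2 to compound 3 (0.37 log units; beyond the scatter). For compound 3 the expected value is 5000 nM, with an estimated range from 1200 nM to 30000 nM.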

Compound 3, half-maximal inhibitory concentration: > 100000 nM
Compound 3 was reported as a limit (the forecaster's own chance of this, stated with the estimate: 15%); middle value at least 20-fold (1.30 log units) away from the limit.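

Changing methyl to cyclopropyl on a nitrogen on an aromatic ring gives an at least 46-fold higher number from compound 2 to compound 3 (1.66 log units; beyond the scatter) in this assay, so what this nitrogen carries matters, and not merely that a nitrogen stands there in place of hydroxy. Cyclopropylamino does not keep what methylamino gained, which leaves compound 2 as the only one of the three with a readable number. The step between compound 1 and compound 3 cannot be read, since both values are limits, and that shared limit caps what can be said about either compound: the limit of > 100000 nM in this assay, at which 2 of the 3 values shown sit.

Going by these compounds, it remains open how far past its limit compound 3 lies. On these data alone, it is also open whether a plain amino group, ethylamino or dimethylamino on the same carbon would stay near compound 2 or fall away as cyclopropylamino does.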